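A few compounds are considered here, and "the series" means these few. Any claim that something is new, unique, unknown or untested is made for them only; others in the source may bear on it.

Measured compounds:
- compound 1 `CN(C)CCNc1nc(NCc2ccco2)c2ccccc2n1`: "not determined" (no result reported)
- compound 2 `Clc1cccc(N2CCN(CCCNc3nc(NCc4ccco4)c4ccccc4n3)CC2)c1Cl`: 3370 nM

In a functional assay on HT-29 cells (Homo sapiens) for cytotoxicity, read by MTT assay, with a stated time of 2 days (on this read-out higher numbers stand for weaker inhibition and lower numbers for stronger inhibition), compound 1 gives "not determined" (no result reported), so it stands nowhere on the numbers shown; no single value exists for it. For the measured compounds named here, compound 2 gives 3370 nM in this assay, and it is the only compound with a number, but it differs from compound 1 in more than one place, so it offers no single step to follow.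

Compound 3 `CCN(CC)CCNc1nc(NCc2ccco2)c2ccccc2n1` is the next compound. It differs from compound 1 in one place: diethylamino in place of dimethylamino on a saturated chain carbon, two bonds along the chain from a nitrogen on an aromatic ring. Going by the values given here, no step between measured compounds shows what this change does in this assay, so the expectation for it rests on nothing more than the one number available. A change of this size, at a saturated chain carbon two bonds along the chain from a nitrogen on an aromatic ring, is expected to move the result by no more than the usual scatter in either direction.

Compound 3 is therefore expected to give about 5000 nM in this assay, with a range from 1000 nM to 30000 nM, guided only by the value of compound 2 at 3370 nM.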

Compound 3, half-maximal inhibitory concentration: 10300 nM
The estimate for compound 3 lay 2.1-fold (0.31 log units) below the measured number; the measured number falls inside the stated range.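

Compound 1 has no single number in this assay, so the change from dimethylamino to diethylamino that gives compound 3, at 10300 nM, cannot be read as a step. The compounds shown leave open how this change alters the result, and no available evidence bears on the value of compound 3.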